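Working notes on a corticotropin releasing factor receptor series

The source may report more compounds than this note shows. Statements on the series, on what has been measured and on what is new or still open speak of the compounds shown alone.

Measured so far in an assay for binding affinity to Corticotropin releasing factor receptor (Rattus norvegicus); on this read-out higher numbers stand for weaker inhibition and lower numbers for stronger inhibition:
- compound 1, `CCCC(C)n1c(CC)nc2c(-c3ccc(OC)nc3C(F)(F)F)ccnc21`: 0.6 nM
- compound 2, `CCc1nc2c(-c3ccc(OC)nc3C)ccnc2n1C(CC)C1CC1`: 0.7 nM

Compound 2 has the higher of the two numbers, but the gap to compound 1 is within the scatter of repeated measurements, so the two compounds are treated as equivalent on this read-out; neither can be called the stronger of the pair.

The next compound is compound 3, `CCCC(C)n1c(CC)nc2c(-c3ccc(OC)nc3C)ccnc21`, which differs from compound 2 in one place: 1-methylbutyl in place of 1-cyclopropylpropyl on an aromatic nitrogen. For the measured compounds named here, no pair of measured compounds shows what this particular exchange does on its own, so there is no measured step to lean on. The two measured compounds, carrying different substituents on the shared core, give values that sit within the scatter of each other, which gives no ground to expect a move in either direction here.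

On that basis compound 3 is expected to give about 0.7 nM in this assay, with a range of 0.3 nM to 1.6 nM. The step from compound 2 to compound 3 is estimated as no change at the digits printed from compound 2 to compound 3 (within the scatter), that is, nothing beyond the scatter.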

Compound 3, inhibition constant: 1.1 nM
For compound 3 the middle estimate is 1.6-fold (0.20 log units) below the measured one; the range from low to high includes it.
By their numbers in this assay, from the lowest: compounds 1, 2 and 3 (each within the scatter of the next).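

In this assay, the exchange of 1-cyclopropylpropyl for 1-methylbutyl on the aromatic nitrogen now has a measured step, a 1.6-fold higher number from compound 2 to compound 3 (0.20 log units; within the scatter) and therefore no detectable effect on this read-out, so the open chain and the cyclopropyl-bearing group cannot be told apart at this position. Compound 3 also adds a second single exchange on the shared core: methyl in place of trifluoromethyl on an aromatic carbon gives a 1.8-fold higher number from compound 1 to compound 3 (0.26 log units; within the scatter) and likewise leaves those two groups indistinguishable here. No measurement at hand bears on the reason for either result.

From the compounds shown here alone, both steps stay within the scatter, so it remains open whether a longer chain or a chain ending in an amine on the aromatic nitrogen, or a methoxy group or chlorine on the aromatic carbon, would separate from these compounds in this assay. Neither step shows how 1-cyclopropylpropyl and trifluoromethyl behave together on the shared core, or whether the two exchanges add up when made at once.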